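Anilino-substituted series: cytotoxicity and the chloro position

The compounds below may be only part of what the source reports. "The series", "measured", "known", "first", "only" and "open" are said of these compounds alone.

Measured so far:
- compound 1 `FC(F)(F)c1ccc(CSc2nc(Nc3ccccc3)c3ccccc3n2)cc1`: 44000 nM
- compound 2 `FC(F)(F)c1ccc(CSc2nc(Nc3ccccc3C(F)(F)F)c3ccccc3n2)cc1`: > 50000 nM
- compound 3 `FC(F)(F)c1ccc(CSc2nc(Nc3ccccc3Cl)c3ccccc3n2)cc1`: > 50000 nM

In a functional assay on MCF7 cells (Homo sapiens) for cytotoxicity, read by MTT assay, with a stated time of 72 h (a lower number here means a stronger inhibitor, a higher number a weaker inhibitor), compound 1 gives 44000 nM. For compound 2 this assay reports only a limit, > 50000 nM. For compound 3 this assay likewise reports only a limit, > 50000 nM. Compound 3 therefore stands at the weak end of what is shown, together with compound 2, where the limit of > 50000 nM in this assay, at which 2 of the 3 values shown sit, applies. The steps of an at least 1.1-fold higher number from compound 1 to compound 2 (0.05 log units; that floor lies within the scatter) and an at least 1.1-fold higher number from compound 1 to compound 3 (0.05 log units; that floor lies within the scatter) both run towards that limit, and the step that the two limits leave unreadable from compound 2 to compound 3 cannot be sized.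

Compound 4 `FC(F)(F)c1ccc(CSc2nc(Nc3cccc(Cl)c3)c3ccccc3n2)cc1` differs from compound 3 in one place: 3-chlorophenyl in place of 2-chlorophenyl on a nitrogen on an aromatic ring. Within the data shown here, no measured step covers a move of the chloro within that ring, so the expectation rests only on the two steps from compound 1, which show that a substituent on this phenyl gives a number no lower than that of compound 1 and reaching the limit in both cases. The step of a number no higher from compound 3 to compound 4 (the limit leaves the size open) is therefore expected to be small or unreadable, with a good chance that the assay again reports only a limit. Compound 4 is estimated at 50000 nM, in the range 20000 nM to 150000 nM.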

Compound 4, half-maximal inhibitory concentration: 25100 nM
For compound 4 the middle estimate is 2.0-fold (0.30 log units) above the measured one; measured number inside the range.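

In this assay, 3-chlorophenyl is the only substituted phenyl shown that gives a number rather than a limit, while compound 2 and compound 3 report only a limit: the limit of > 50000 nM in this assay, at which 2 of the 4 values shown sit.

From the compounds shown here alone, the move of the chloro within the ring is read as an at least 1.9-fold lower number from compound 3 to compound 4 (0.29 log units; that floor lies within the scatter), and the exchange for the trifluoromethyl-bearing ring as an at least 1.9-fold lower number from compound 2 to compound 4 (0.29 log units; that floor lies within the scatter); both are floors, so the true sizes stay open and neither floor alone separates these compounds beyond the scatter. Set against the unsubstituted phenyl, the result is a 1.8-fold lower number from compound 1 to compound 4 (0.24 log units; within the scatter), so a chloro on this ring does not always go with reaching the limit, and 3-chlorophenyl cannot be told apart from the plain phenyl.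

The compounds shown leave open whether 3-(trifluoromethyl)phenyl would also give a number, which would show whether this behaviour belongs to the ring position or to the chloro alone. They also say nothing about how an amine or a carboxylic acid on this phenyl would read, or about any change to the rest of the shared core.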